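The compounds below may be only part of what the source reports. "The series", "measured", "known", "first", "only" and "open" are said of these compounds alone.

Measured compounds in an assay on isolated protein for inhibition of ribosomal protein S6 kinase alpha-5 (Homo sapiens), read by mobility shift assay, tested at 30 uM; a lower number here means less inhibition, a higher number more inhibition at the concentration tested (going by the name of the read-out):
- compound 1 `CC(=O)Nc1nn(C)c2cc(-c3ccccc3)[nH]c(=O)c12`: 3%
- compound 2 `COc1ccc(S(=O)(=O)Nc2nn(C)c3cc(C)[nH]c(=O)c23)c(OC)c1`: 3%
- compound 3 `Cc1cc2nn(-c3ccccc3)c(N)c2c(=O)[nH]1`: 4%

Compound 3 carries the highest number of the three, but its distance to compound 1 and to compound 2 lies within the scatter, so the three read as one flat group of low inhibition and no ordering among them can be claimed. No pair of these compounds differs in a single place, so no measured step is available.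

Compound 4 `CC(C)(C)c1cc2nn(-c3ccccc3)c(N)c2c(=O)[nH]1` is the next member. It differs from compound 3 as follows: tert-butyl in place of methyl on an aromatic carbon

With every measured number in this assay sitting at the same low level, nothing in the series suggests that exchanging methyl for tert-butyl at that position moves the read-out. The expectation for this assay is no step beyond the scatter, in either direction, from compound 3 to compound 4. Compound 4 is therefore expected to give 4%, with a range of -5% to 15%, meaning an expected step of no change at the digits printed from compound 3 to compound 4 (within the scatter).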

Compound 4, a percentage reported as inhibition, at one concentration (the size of the read-out at that concentration, not a potency): -1%
Beside the measured number, compound 4's estimate is 5 percentage points above it; measured number inside the range.
By their numbers in this assay, from the lowest: compounds 4, 1, 2 and 3 (each within the scatter of the next).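

In this assay the exchange of methyl for tert-butyl on the aromatic carbon next to the ring nitrogen gives a number 5 percentage points lower from compound 3 to compound 4 (within the scatter) and so supplies the first single-place step measured in this series. At this position, going from a group of 1 heavy atom to one of 4 heavy atoms brings no gain beyond the scatter, and from so low a starting level a loss could hardly show.

As far as these compounds go, whether an amine or a carboxylic acid on this aromatic carbon would lift the read-out stays open. Also open, from the compounds shown here alone, is whether any compound on the shared core reaches a level of inhibition at which a step at this position could be read. No measured evidence bears on this step.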